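Replacing the dimethylphenyl on the ring amine nitrogen

The source may report more compounds than this note shows. Statements on the series, on what has been measured and on what is new or still open speak of the compounds shown alone.

Compound 1 `Cc1nc(-c2ccccc2)c(C(=O)N2CCN(c3cccc(C)c3C)CC2)o1`: in a functional assay on HL-60 cells (Homo sapiens) for inhibition, read by MTT assay, with a stated time of 72 h (a lower number here means a stronger inhibitor, a higher number a weaker inhibitor), compound 1 gives 35 nM.
Compound 2 `Cc1ccc(C)c(N2CCN(C(=O)c3oc(C)nc3-c3ccccc3Cl)CC2)c1`: in this assay compound 2 gives only a limit, > 1000 nM.
Compound 3 `Cc1nc(-c2ccc(F)cc2)c(C(=O)N2CCN(c3cc(Cl)cc(Cl)c3)CC2)o1`: in this assay compound 3 gives 52.1 nM.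

Of the two numbers shown, compound 1 has the lower, but compound 3 lies within the usual scatter of it, so neither can be ranked ahead of the other. The result for compound 2 is a limit of the assay, not a number (the limit of > 1000 nM in this assay, at which 1 of the 3 values shown sits). Compound 4 `Cc1nc(-c2ccccc2)c(C(=O)N2CCN(c3cccc(C#N)c3)CC2)o1` differs from compound 1 in a single place: 3-cyanophenyl in place of 2,3-dimethylphenyl on an amine nitrogen in a ring. Within the data shown here, no measured pair shows this exchange, so the size of the step is unknown; a moderate weakening, somewhat beyond the scatter, is expected. In this assay compound 4 is expected to give about 150 nM, with a range from 40 nM to 800 nM. That estimate corresponds to an expected step of a 4.3-fold higher number from compound 1 to compound 4 (0.63 log units; beyond the scatter).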

Compound 4, half-maximal inhibitory concentration: 39.6 nM
The estimate for compound 4 lay 3.8-fold (0.58 log units) above the measured number; the whole stated range lies above it.
By their numbers in this assay, from the lowest: compounds 1, 4 and 3 (each within the scatter of the next). At a limit, above all of these: compound 2.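

Replacing 2,3-dimethylphenyl with 3-cyanophenyl on the amine nitrogen in the ring gives, in this assay, a step of a 1.1-fold higher number from compound 1 to compound 4 (0.05 log units; within the scatter). This is the first exchange shown that changes only this place, and it shows that an aromatic ring carrying a nitrile, with its one hydrogen-bond acceptor, can stand here with no step beyond the scatter. Nothing shown accounts for this result.

Going by these compounds, it remains open whether a phenyl bearing a carboxylic acid or an amine would fare likewise. The same holds for a saturated group such as cyclohexyl on that nitrogen.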